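The source may hold more compounds than are shown below. What is called first, only, known or untested is meant among the compounds shown, and "the series" means these compounds.

Compound 1 `Nc1cc(N)c2nc(-c3ccccc3)c(Oc3ccc(Cl)c(Cl)c3)nc2c1` gives in a functional assay on K562 cells (Homo sapiens) for inhibition, read by sulforhodamine B assay, with a stated time of 48 h (on this read-out higher numbers stand for lower toxicity in this test and lower numbers for higher toxicity in this test), the limit < 100000 nM.
Compound 2 `CCOC(=O)[C@H](CCC(=O)O)NC(=O)c1ccc(CNc2nc3cc(N)cc(N)c3nc2-c2ccccc2)cc1` gives in this assay the limit < 100000 nM.
Compound 3 `Nc1cc(N)c2nc(-c3ccccc3)c(NCc3ccc(Cl)c(Cl)c3)nc2c1` gives in this assay the limit < 100000 nM.

Compound 3 therefore stands nowhere in particular among the numbers shown: its result in this assay is a limit and not a number, and the same holds for the other two compounds, which is summed up by the limit of < 100000 nM in this assay, at which 3 of the 3 values shown sit. Within the data shown here, no step between two measured compounds that differ in one place is available, so no measured change can guide the next compound.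

Compound 4 `COc1ccc(CNc2nc3cc(N)cc(N)c3nc2-c2ccccc2)cc1` differs from compound 3 by 4-methoxyphenyl in place of 3,4-dichlorophenyl on a saturated chain carbon bound to a nitrogen on an aromatic ring. With every measured result sitting at the limit, there is no basis for expecting a step in either direction beyond the scatter; the step from compound 3 to compound 4 is expected to be a step that the limit leaves unreadable from compound 3 to compound 4, and the result for compound 4 is expected most likely to be reported again as a limit. Compound 4 is estimated in this assay at 60000 nM, within a range from 8000 nM to 100000 nM.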

Compound 4, concentration lethal to 50% of the cells: < 100000 nM
Compound 4: no number, only a limit; the forecaster's own chance of this, stated with the estimate: 75%; the middle value does not contradict the limit.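

Among these compounds, compound 4, like compound 3, is reported only as a limit, so no step from compound 3 to compound 4 can be read in this assay. The compounds shown leave open what number any of them would give, and so whether 4-methoxyphenyl in place of 3,4-dichlorophenyl changes the result: the limit of < 100000 nM in this assay, at which 4 of the 4 values shown sit.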